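This account rests on a few compounds, and the source may have more. Where it says the series, first, only, none or still open, it means among the compounds named here.

In a functional assay on MCF7 cells (Homo sapiens) for cytotoxicity, read by MTT assay, with a stated time of 48 h (a lower number here means a stronger inhibitor, a higher number a weaker inhibitor), compound 1 `Cc1ncc([N+](=O)[O-])n1CCSc1nnc(-c2ccccc2N)o1` gives 20100 nM. Beside it, compound 2 `CCOc1ccccc1-c1nnc(SCCn2c([N+](=O)[O-])cnc2C)o1` gives 25900 nM and compound 3 `Cc1ncc([N+](=O)[O-])n1CCSc1nnc(-c2ccccc2[N+](=O)[O-])o1` gives 18300 nM, so compound 1 stands in a tight group, with all three values within the scatter of each other. Compound 4 `Cc1ccc(-c2nnc(SCCn3c([N+](=O)[O-])cnc3C)o2)c(O)c1` differs from compound 1 in one place: 2-hydroxy-4-methylphenyl in place of 2-aminophenyl on an aromatic carbon. Two measured steps replace the same amino group, and both are small: a 1.3-fold higher number from compound 1 to compound 2 (0.11 log units; within the scatter) and a 1.1-fold lower number from compound 1 to compound 3 (0.04 log units; within the scatter). Going by the values given here, no measured compound carries the hydroxy or methyl group, so this change is untested directly. In this assay the estimated result is a 1.0-fold higher number from compound 1 to compound 4 (0.02 log units; within the scatter), which means no expected change beyond the scatter. The estimate for compound 4 is 21000 nM, with an expected range from 11000 nM to 40000 nM.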

Compound 4, half-maximal inhibitory concentration: 23500 nM
The estimate for compound 4 lay 1.1-fold (0.05 log units) below the measured number; low and high end bracket the measured number.
By their numbers in this assay, from the lowest: compounds 3, 1, 4 and 2 (each within the scatter of the next).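

In this assay, the step (a 1.2-fold higher number from compound 1 to compound 4 (0.07 log units; within the scatter)) shows that this position can take a group that differs from 2-aminophenyl in two ways, with hydroxy replacing amino and a methyl added. Earlier steps from compound 1 replaced only the amino group, and this larger change also stays within the scatter. No measurement shown gives a reason for this flat result. Still open, going by these compounds, is whether any group here can move the number beyond the scatter, such as a carboxylic acid on the aromatic ring or a morpholine.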